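This account rests on a few compounds, and the source may have more. Where it says the series, first, only, none or still open, it means among the compounds named here.

Compound 1 `Cc1ccc(NC(=O)Nc2cc(-c3ccccc3C(=O)O)ccc2Nc2ccccc2C(C)(C)C)cc1` gives 600 nM in an assay on HeLa cells for inhibition of Indoleamine 2,3-dioxygenase 1 (Homo sapiens), with stated times of 1 h and 18 h; a lower number here means a stronger inhibitor, a higher number a weaker inhibitor.
Compound 2 `Cc1ccc(NC(=O)Nc2cc(-c3ccccc3C(=O)O)ccc2N(C)c2ccccc2C(C)(C)C)cc1` gives > 1000 nM in this assay, which is a limit of the assay rather than a number.
Compound 3 `Cc1ccc(NC(=O)Nc2cc(-c3ccccc3C(=O)O)ccc2NC2CCCCC2)cc1` gives 504 nM in this assay.

Compound 2 stands at the edge of the numbers shown: of the three results, its result is the only one that is a limit (the limit of > 1000 nM in this assay, at which 1 of the 3 values shown sits). Compound 4 `Cc1ccc(NC(=O)Nc2cc(-c3ccccc3C(=O)O)ccc2N2CCC[C@@H]3CCCC[C@@H]32)cc1` differs from compound 2 in one place: a group of 10 heavy atoms (9 carbon, 1 nitrogen; one six-membered non-aromatic ring of carbon only, one six-membered non-aromatic ring with 1 hetero atom) in place of a group of 12 heavy atoms (11 carbon, 1 nitrogen; one six-membered aromatic ring of carbon only), on an aromatic carbon. Going by the values given here, two measured steps bear on this change. Swapping the same group for cyclohexylamino gave an at least 1.9-fold lower number from compound 2 to compound 3 (0.29 log units; that floor lies within the scatter). Adding a methyl to the ring nitrogen gave an at least 1.6-fold higher number from compound 1 to compound 2 (0.22 log units; that floor lies within the scatter). Compound 4 carries a saturated ring, as compound 3 does, but its nitrogen bears no hydrogen, as in compound 2. The saturated ring points toward a lower number, while the missing hydrogen on the nitrogen points the other way, so only a small step beyond the scatter is expected in this assay. Compound 4 is expected to give 900 nM, with a range from 400 nM to 2500 nM. This estimate means a step of an at least 1.1-fold lower number from compound 2 to compound 4 (0.04 log units; that floor lies within the scatter).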

Compound 4, half-maximal inhibitory concentration: 159 nM
For compound 4 the middle estimate is 5.7-fold (0.75 log units) above the measured one, and the stated range ends above it.
By their numbers in this assay, from the lowest: compound 4; then compounds 3 and 1 (each within the scatter of the next). At a limit, above all of these: compound 2.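

In this assay, the two-ring group of compound 4, on an aromatic carbon para to a 2-carboxyphenyl group, brings an at least 6.2-fold lower number from compound 2 to compound 4 (0.79 log units; beyond the scatter), which is only a floor, since compound 2 carries a limit of the assay and not a number: the limit of > 1000 nM in this assay, at which 1 of the 4 values shown sits.

The same group also improves on the two groups that keep a hydrogen on the nitrogen, with a 3.2-fold lower number from compound 3 to compound 4 (0.50 log units; beyond the scatter) and a 3.8-fold lower number from compound 1 to compound 4 (0.58 log units; beyond the scatter). The earlier compounds shown here left open whether that hydrogen was needed, but compound 4 has none and still gives the lowest number of the four, so at this position a nitrogen without it can carry a stronger inhibitor, and in compound 2 and compound 4 the outcome depends on the rest of the group.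

From the compounds shown here alone, compound 4 has two defined stereocentres and only this one arrangement appears here, so what the arrangement contributes stays open. Going by these compounds, it is also open whether both saturated rings matter, a question that a single piperidin-1-yl or morpholin-4-yl group on the same carbon would address.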